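The source may hold more compounds than are shown below. What is called first, only, known or untested is meant among the compounds shown, and "the series" means these compounds.

Measured so far:
compound 1 `c1csc(-c2ccccc2NCC2=NCCN2)c1`: 2.24 nM
compound 2 `CCO/N=C(\C)c1ccccc1NCC1=NCCN1`: 52.5 nM

Among the compounds with values here, in a functional assay for activation of Alpha-1A adrenergic receptor (Homo sapiens), read by calcium flux (on this read-out higher numbers stand for an effect only at larger amounts of compound and lower numbers for an effect already at smaller amounts), compound 2 gives 52.5 nM, the highest of the two numbers; the only other point is compound 1, which gives 2.24 nM, and the step of a 23-fold higher number from compound 1 to compound 2 (1.37 log units; beyond the scatter) is large. Compound 3 `CO/N=C/c1ccccc1NCC1=NCCN1` has not been measured. It differs from compound 2 by a group of 4 heavy atoms (2 carbon, 1 nitrogen, 1 oxygen; no ring) in place of a group of 6 heavy atoms (4 carbon, 1 nitrogen, 1 oxygen; no ring), on an aromatic carbon. Within the data shown here, no measured step matches this change, since the one known step swaps a different group, so the expectation rests on compound 2 alone. Compound 3 is therefore expected near compound 2, with a 1.2-fold lower number from compound 2 to compound 3 (0.07 log units; within the scatter) as the estimated step, giving an estimate of 45 nM with a range from 10 nM to 200 nM.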

Compound 3, half-maximal effective concentration: 51.3 nM
Estimate against measurement, compound 3: 1.1-fold (0.06 log units) below, within the range that was stated.
By their numbers in this assay, from the lowest: compound 1; then compounds 3 and 2 (each within the scatter of the next).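

In this assay, a group of 4 heavy atoms in place of a group of 6 heavy atoms on this aromatic carbon makes no difference beyond the scatter (a 1.0-fold lower number from compound 2 to compound 3 (0.01 log units; within the scatter)). The gap to the five-membered aromatic ring of compound 1 therefore remains large with either open-chain group (a 23-fold higher number from compound 1 to compound 3 (1.36 log units; beyond the scatter)). Nothing measured here gives a reason for that gap. From the compounds shown here alone, whether a phenyl ring or an amine on this aromatic carbon would bring the number closer to that of compound 1 stays open, as does the effect of a longer chain.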